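This account rests on a few compounds, and the source may have more. Where it says the series, first, only, none or still open, it means among the compounds named here.

Measured compounds in a functional assay on the whole organism (Hindlimb, strain albino) with Mus musculus as the target, in the maximal electroshock model, with a stated time of 0.5 h; on this read-out higher numbers stand for an effect only at larger amounts of compound and lower numbers for an effect already at smaller amounts:

- compound 1 `COc1ccc(C2CC(Nc3nc4ccc(C)cc4s3)=NN2C(C)=O)cc1`: 37.3 umol/kg
- compound 2 `O=C(/C=C/OC1=CC=C1)Nc1nc2ccccc2s1`: 781 umol/kg
- compound 3 `O=C(/C=C/OC1=CC=C1)Nc1nc2ccc(Cl)cc2s1`: 544 umol/kg

Compound 2 stands at the highest of the three numbers. Going by the values given here, its nearest neighbour is compound 3, where the only change is chloro in place of hydrogen on an aromatic carbon: a 1.4-fold lower number from compound 2 to compound 3 (0.16 log units; within the scatter). Among the compounds with values here, compound 1, built on a different core, sits far lower, and no single step connects it to compound 2.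

The unmeasured compound 4 `O=C(/C=C/c1ccc(O)cc1)Nc1nc2ccccc2s1` is reached from compound 2 by the change (a group of 7 heavy atoms (6 carbon, 1 oxygen; one six-membered aromatic ring of carbon only) in place of a group of 5 heavy atoms (4 carbon, 1 oxygen; one four-membered non-aromatic ring of carbon only), on a double-bonded chain carbon bound to a double-bonded chain carbon).

Within the data shown here, no measured step touches this change; the one step recorded, from compound 2 to compound 3, alters only a substituent on the shared core and says nothing about the chain end. The comparison with compound 1 shows that much lower numbers occur in this assay, but across a different core. Direction and size therefore rest on no direct precedent; a moderate move is allowed for by widening the range. Compound 4 is estimated at 450 umol/kg (range 150 umol/kg to 1200 umol/kg), an expected step of a 1.7-fold lower number from compound 2 to compound 4 (0.24 log units; within the scatter).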

Compound 4, dose for half-maximal effect: 517 umol/kg
For compound 4 the middle estimate is 1.1-fold (0.06 log units) below the measured one; the range from low to high includes it.
By their numbers in this assay, from the lowest: compound 1; then compounds 4, 3 and 2 (each within the scatter of the next).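

In this assay, 4-hydroxyphenyl in place of the group with the four-membered non-aromatic ring gives a 1.5-fold lower number from compound 2 to compound 4 (0.18 log units; within the scatter), on a double-bonded chain carbon bound to a double-bonded chain carbon. This position thus accepts a six-membered aromatic ring and a hydrogen-bond donor with no change beyond the scatter, which the chloro step on the shared core could not show. Nothing at hand offers an explanation for this result.

Open, as far as these compounds go, is whether an unsubstituted phenyl at this place would read the same as 4-hydroxyphenyl, which would separate the contribution of the ring from that of its hydroxyl. Also open, from the compounds shown here alone, is whether an amine or a carboxylic acid on that ring, or a longer chain at this place, would give a step beyond the scatter.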